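A Second Methyl on the Benzamide Ring

The source may report more compounds than this note shows. Statements on the series, on what has been measured and on what is new or still open speak of the compounds shown alone.

Compound 2 `Cc1ccc(C(=O)Nc2cccc(-c3oc4cc(-c5ccc(F)cc5)ccc4c(=O)c3O)c2)cc1` gives 6190 nM in a functional assay on HeLa cells (Homo sapiens) for antiproliferative activity, read by CCK-8 assay, with a stated time of 72 h (a higher number here means a weaker inhibitor, a lower number a stronger inhibitor), and holds the second highest of the three measured numbers. Its nearest neighbour, compound 1 `COc1ccc(C(=O)Nc2cccc(-c3oc4cc(-c5ccc(F)cc5)ccc4c(=O)c3O)c2)cc1`, gives 4820 nM, with a 1.3-fold higher number from compound 1 to compound 2 (0.11 log units; within the scatter). Compound 3 `CCc1ccc(C(=O)Nc2cccc(-c3oc4cc(-c5ccc(F)cc5)ccc4c(=O)c3O)c2)cc1` gives 21000 nM; here a 3.4-fold higher number from compound 2 to compound 3 (0.53 log units; beyond the scatter), and a 4.4-fold higher number from compound 1 to compound 3 (0.64 log units; beyond the scatter). Compound 4 `Cc1cc(C)cc(C(=O)Nc2cccc(-c3oc4cc(-c5ccc(F)cc5)ccc4c(=O)c3O)c2)c1` carries 3,5-dimethylphenyl in place of 4-methylphenyl on a carbonyl carbon. Among the compounds with values here, the only measured step that enlarges this part of the molecule, methyl in place of hydrogen on a saturated chain carbon, weakened inhibition modestly, and no measured step places a second methyl on the ring. A modest weakening is therefore expected, a 1.6-fold higher number from compound 2 to compound 4 (0.21 log units; within the scatter), though the scatter leaves room for no change. Compound 4 is estimated at 10000 nM, within 4000 nM to 25000 nM.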

Compound 4, half-maximal inhibitory concentration: 5540 nM
Beside the measured number, compound 4's estimate is 1.8-fold (0.26 log units) above it; the measured number falls inside the stated range.
By their numbers in this assay, from the lowest: compounds 1, 4 and 2 (each within the scatter of the next); then compound 3.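

The extra carbon on this ring costs nothing that can be read in this assay: 3,5-dimethylphenyl in place of 4-methylphenyl on a carbonyl carbon stays within the scatter (a 1.1-fold lower number from compound 2 to compound 4 (0.05 log units; within the scatter)), as it does in place of 4-methoxyphenyl (a 1.1-fold higher number from compound 1 to compound 4 (0.06 log units; within the scatter)). Added size alone therefore does not track the number, since 4-ethylphenyl remains apart from the 3,5-dimethylphenyl group, which has one more heavy atom (a 3.8-fold lower number from compound 3 to compound 4 (0.58 log units; beyond the scatter)). No evidence at hand explains this difference.

On these data alone, whether a single methyl at the 3 position, a 3,5-dimethoxyphenyl group or an amine on this ring would keep the number in this range stays open.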